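The source may hold more compounds than are shown below. What is called first, only, known or untested is meant among the compounds shown, and "the series" means these compounds.

Three compounds share one core and differ only in a single group on the aromatic ring. Compound 1 `CCC(COc1cccc(Cl)c1)OC(=O)NCc1ccccc1` carries a chloro group, compound 2 `CCC(COc1cccc([N+](=O)[O-])c1)OC(=O)NCc1ccccc1` a nitro group, and compound 3 `CCC(COc1cccc(C)c1)OC(=O)NCc1ccccc1` a methyl group. In an assay for inhibition of zeta-carotene desaturase, chloroplastic/chromoplastic (Capsicum annuum), using a Dixon plot, with a stated time of 8 h (a lower number here means a stronger inhibitor, a higher number a weaker inhibitor), compound 1 gives only a limit of the assay, > 100000 nM. In this assay compound 2 likewise gives a limit, > 100000 nM. In this assay compound 3 also reaches only a limit, > 100000 nM. Compound 3 thus stands at the limit of > 100000 nM in this assay, at which 3 of the 3 values shown sit. The steps a step that the two limits leave unreadable from compound 1 to compound 3 and a step that the two limits leave unreadable from compound 2 to compound 3 are unreadable in size, as is a step that the two limits leave unreadable from compound 1 to compound 2. Compound 4 `CCOC(=O)c1cccc(OCC(CC)OC(=O)NCc2ccccc2)c1` differs from compound 3 by ethoxycarbonyl in place of methyl on an aromatic carbon. Going by the values given here, no measured step is readable in size, so the expected step that the limit leaves unreadable from compound 3 to compound 4 is taken as none beyond the scatter. Compound 4 is expected to give 150000 nM, with a range from 30000 nM to 1000000 nM.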

Compound 4, half-maximal inhibitory concentration: > 100000 nM
Compound 4 gave a limit, no number (the forecaster's own chance of this, stated with the estimate: 85%); the middle value does not contradict the limit.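

Going by these compounds alone, compound 4 also gives only a limit, so no step from compound 1, compound 2 or compound 3 to compound 4 can be read in size. The compounds shown leave open whether any group on the aromatic ring of the shared core would give a readable number.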